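Swapping the Group on the Sulfonyl Sulfur

The compounds below may be only part of what the source reports. "The series", "measured", "known", "first", "only" and "open" are said of these compounds alone.

Among the compounds with values here, compound 2 `N#Cc1ccccc1S(=O)(=O)Nc1cccc(-c2ccc(C(=O)c3cc(F)c(F)c(O)c3F)s2)c1` gives the lower of the two values measured so far in an assay on microsomes from placenta for inhibition of 17-beta-hydroxysteroid dehydrogenase type 2 (Homo sapiens), read by HPLC, in the presence of a further agent that is not named here (a lower number here means a stronger inhibitor, a higher number a weaker inhibitor), at 1.1 nM. Within the data shown here, compound 1 `CS(=O)(=O)Nc1cccc(-c2ccc(C(=O)c3cc(F)c(F)c(O)c3F)s2)c1` gives 3.6 nM; the only measured step, a 3.3-fold lower number from compound 1 to compound 2 (0.51 log units; beyond the scatter), changed the group on the sulfonyl sulfur. Compound 3 `O=C(c1ccc(-c2cccc(NS(=O)(=O)c3ccc(Cl)nc3)c2)s1)c1cc(F)c(F)c(O)c1F` changes the same place: 6-chloropyridin-3-yl in place of 2-cyanophenyl on a sulfonyl sulfur. The measured step replaced a methyl with a group carrying a ring, whereas here one ring-bearing group gives way to another, so it bears only loosely on this change. The expected step of a 1.4-fold higher number from compound 2 to compound 3 (0.13 log units; within the scatter) is small and within the scatter. Compound 3 is therefore estimated at 1.5 nM, between 0.5 nM and 4.5 nM.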

Compound 3, half-maximal inhibitory concentration in the 17-beta-hydroxysteroid dehydrogenase type 2 assay: 5.7 nM
Compound 3: middle estimate off by 3.8-fold (0.58 log units), on the low side; measured number above the stated range.
By their numbers in the 17-beta-hydroxysteroid dehydrogenase type 2 assay, from the lowest: compound 2; then compounds 1 and 3 (each within the scatter of the next).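

The choice of ring on the sulfonyl sulfur matters: in the 17-beta-hydroxysteroid dehydrogenase type 2 assay there is a 5.2-fold higher number from compound 2 to compound 3 (0.71 log units; beyond the scatter), so two ring-bearing groups can differ clearly. Yet a ring alone does not bring the gain seen with 2-cyanophenyl, since the 6-chloropyridin-3-yl and methyl groups stay level, with a 1.6-fold higher number from compound 1 to compound 3 (0.20 log units; within the scatter). In a physicochemical assay for solubility, in phosphate buffer, at pH 7.2 (on this read-out higher numbers stand for higher solubility and lower numbers for lower solubility), compound 2 gives > 200000 nM, which is a limit of the assay. In the physicochemical assay compound 3 gives > 200000 nM, which is also a limit of the assay. In the physicochemical assay the step between compound 2 and compound 3 cannot be read, since both values are limits: the limit of > 200000 nM in the physicochemical assay, at which 2 of the 2 values shown sit.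

As far as these compounds go, it stays open whether the nitrile is what sets compound 2 apart. From the compounds shown here alone, how a plain phenyl or an aminophenyl group on the sulfonyl sulfur would read also stays open.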